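Trifluoromethyl for methyl on the six-membered ring of compound 2

The source may report more compounds than this note shows. Statements on the series, on what has been measured and on what is new or still open speak of the compounds shown alone.

Compound 1 `Fc1ccc2nc(-c3cnco3)n(C3CC3)c2c1` reaches only a limit in an assay on cells for inhibition of cytochrome P450 11B2, mitochondrial (Homo sapiens), read by HPLC, with a stated time of 90 min (a lower number here means a stronger inhibitor, a higher number a weaker inhibitor), and shows > 10000 nM there, which is the limit of > 10000 nM in this assay, at which 1 of the 2 values shown sits. Among the compounds with values here, compound 2 `Cc1ncncc1-c1nc2cc(F)c(F)cc2n1C1CC1` gives 17 nM in this assay and carries the only numerical value in the set so far. Compound 3 `Fc1cc2nc(-c3cncnc3C(F)(F)F)n(C3CC3)c2cc1F` differs from compound 2 by trifluoromethyl in place of methyl on an aromatic carbon. Within the data shown here, no measured pair of this kind is available, so the step is open. For compound 3 a modest loss of potency is expected, with a 2.9-fold higher number from compound 2 to compound 3 (0.47 log units; beyond the scatter) as the estimated step. Compound 3 is estimated at 50 nM in this assay, with a range from 10 nM to 300 nM.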

Compound 3, half-maximal inhibitory concentration: 25 nM
For compound 3 the middle estimate is 2.0-fold (0.30 log units) above the measured one; the measured number falls inside the stated range.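

Trifluoromethyl in place of methyl on an aromatic carbon of the six-membered aromatic ring with 2 nitrogen gives, in this assay, a 1.5-fold higher number from compound 2 to compound 3 (0.17 log units; within the scatter). Within the data shown here, this is the first step read at this position, and it shows that the position takes either group with no difference that stands out from the scatter. Among these compounds, nothing measured so far bears on why the two groups read alike.

As far as these compounds go, whether an amine, a methoxy group or a longer chain at this position would read the same stays open. So does whether a hydrogen there would hold the value.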